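The compounds below may be only part of what the source reports. "The series", "measured", "known", "first", "only" and "open" are said of these compounds alone.

In an ADME assay on Vero cells (Chlorocebus sabaeus) for cytotoxicity, read by neutral red uptake, tested at 25 ug/mL (on this read-out lower numbers stand for a stronger effect and higher numbers for a weaker effect at the one concentration tested), compound 1 `COc1ccc(C2SCC(=O)N2CCN2CCCCC2)cc1` gives 100%. Compound 2 `O=C1CSC(c2ccc(O)cc2)N1CCN1CCCCC1` differs from it only by a hydrogen in place of methyl on an oxygen on an aromatic ring, and in this assay compound 2 gives 100%; the step of no change at the digits printed from compound 1 to compound 2 (within the scatter) lies within the scatter, so compound 2 stands level with compound 1 on this number, and both sit at the end of the scale that means the weakest effect. Compound 3 `O=C1CSC(c2ccc([N+](=O)[O-])cc2)N1CCN1CCCCC1` is the next compound: nitro in place of hydroxy on an aromatic carbon. Within the data shown here, the only measured step, no change at the digits printed from compound 1 to compound 2 (within the scatter), swapped one small group on the aromatic ring for another and left the read-out unmoved, so no step beyond the scatter is expected here in either direction. Compound 3 is therefore expected to give 100%, with a range from 85% to 100%, an expected step of no change at the digits printed from compound 2 to compound 3 (within the scatter).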

Compound 3, a percentage reported as activity, at one concentration (the size of the read-out at that concentration, not a potency): 100%
Compound 3: the middle estimate sits on the measured number at the digits printed; the range from low to high includes it.
By their numbers in this assay, from the lowest: compounds 1, 2 and 3 (each within the scatter of the next).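

In this assay, nitro in place of hydroxy on this aromatic carbon, para to a large group, gives no change at the digits printed from compound 2 to compound 3 (within the scatter), and nitro in place of methoxy gives no change at the digits printed from compound 1 to compound 3 (within the scatter). The earlier swap was a small one. This swap is bigger: a group of 3 heavy atoms replaces one of 1 heavy atom, with 0 hydrogen-bond donors instead of 1, and the read-out still does not separate the compounds. Nothing measured here explains this outcome.

As far as these compounds go, it remains open whether an amine, a carboxylic acid or a chlorine atom at this place would read the same, and whether changes elsewhere in the shared core would. From the compounds shown here alone, all three compounds sit at the weak-effect end of the scale, so it is also open which group, if any, would bring the number down.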